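This account rests on a few compounds, and the source may have more. Where it says the series, first, only, none or still open, it means among the compounds named here.

Measured compounds:
- compound 1, `CCCCCCCCCCn1cc(-c2nc3ccccc3cc2CCC)nn1`: > 100 ug/mL in a functional assay on THP-1 cells (Homo sapiens) for cytotoxicity, read by MTT assay, with a stated time of 24 h; a higher number here means a weaker inhibitor, a lower number a stronger inhibitor
- compound 2, `Cc1cc2ccccc2nc1-c1cn(-c2ccc(F)cc2)nn1`: > 100 ug/mL
- compound 3, `CCCCCCCCCCn1cc(-c2nc3ccccc3cc2C)nn1`: > 100 ug/mL

Each of these values is a limit of this assay and not a number. Compound 2 therefore stands only at a limit, as do the two others. The unmeasured compound 4, `CCCCc1cc2ccccc2nc1-c1cn(-c2ccc(F)cc2)nn1`, differs from compound 2 by propyl in place of hydrogen on a saturated chain carbon bound to an aromatic carbon. For the measured compounds named here, the one measured step that touches this change, a step that the two limits leave unreadable from compound 1 to compound 3, is of a size the two limits leave unreadable; the account notes (the limit of > 100 ug/mL in this assay, at which 3 of the 3 values shown sit). Going by the values given here, no measured step therefore tells how large the change in this assay should be. The step from compound 2 to compound 4 is expected to be a step that the limit leaves unreadable from compound 2 to compound 4, with compound 4 most likely again at the limit. Compound 4 is estimated at 150 ug/mL, between 80 ug/mL and 300 ug/mL.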

Compound 4, half-maximal inhibitory concentration: 78.3 ug/mL
For compound 4 the middle estimate is 1.9-fold (0.28 log units) above the measured one; the whole stated range lies above it.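

In this assay, propyl in place of hydrogen on a saturated chain carbon bound to an aromatic carbon gives an at least 1.2-fold lower number from compound 2 to compound 4 (0.10 log units; that floor lies within the scatter). The value of compound 2 is a limit of the assay and not a number, so this floor does not give the true size of the step. Compound 4 is the only compound shown that comes off that limit: the limit of > 100 ug/mL in this assay, at which 3 of the 4 values shown sit.

The step from compound 1 to compound 3 cannot be read. On these data alone, whether an amine or a longer chain in place of propyl would give a step beyond the scatter stays open.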